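This account rests on a few compounds, and the source may have more. Where it says the series, first, only, none or still open, it means among the compounds named here.

Measured in an ADME assay on microsomes from liver (Homo sapiens) for metabolic stability, read by LC-MS, using NADPH, tested at 5 uM; a higher number here means that the compound lasts longer, a lower number that the compound disappears faster:

Compound 1 `Cc1cc(-c2ccccc2)n(/C(N)=N/S(=O)(=O)c2cc(C)c(Cl)cc2SCc2cccc3ccccc23)n1`: 0.256 h
Compound 2 `Cc1cc(-c2ccccc2)n(/C(N)=N/S(=O)(=O)c2cc(C)c(Cl)cc2SCc2cccc(Cl)c2)n1`: 0.205 h
Compound 3 `Cc1cc(S(=O)(=O)/N=C(\N)n2nccc2-c2ccccc2)c(SCc2cccc3ccccc23)cc1Cl`: 0.268 h

Compound 3 gives the largest of the three numbers as written, but it is not separated from compound 1 or from compound 2 beyond the scatter; the three values sit close together. The step from compound 1 to compound 3 is a 1.0-fold higher number from compound 1 to compound 3 (0.02 log units; within the scatter), so hydrogen in place of methyl on the aromatic carbon of the shared core leaves this assay unmoved.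

Compound 4 `Cc1cc(S(=O)(=O)/N=C(\N)n2nccc2-c2ccccc2)c(SCc2ccc(Cl)cc2)cc1Cl` has not yet been measured in this assay. It differs from compound 3 by 4-chlorophenyl in place of naphthalen-1-yl on a saturated chain carbon bound to a sulfur. Within the data shown here, the one measured step that bears on this is the exchange on the same chain carbon between compound 1 and compound 2, a 3-chlorophenyl in place of naphthalen-1-yl, which gave a 1.2-fold lower number from compound 1 to compound 2 (0.10 log units; within the scatter). That pair carries the methyl on the core, but since the methyl-to-hydrogen step above is flat, the pair transfers to the compound 3 scaffold. A chlorophenyl for the naphthalenyl is therefore expected to give at most a small step, a 1.2-fold lower number from compound 3 to compound 4 (0.09 log units; within the scatter), and nothing beyond the scatter. The half-life of compound 4 in this assay is estimated at 0.22 h, with a range of 0.12 h to 0.4 h.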

Compound 4, half-life: 0.34 h
For compound 4 the middle estimate is 1.5-fold (0.19 log units) below the measured one; low and high end bracket the measured number.
By their numbers in this assay, from the lowest: compounds 2, 1, 3 and 4 (each within the scatter of the next).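

In this assay, 4-chlorophenyl in place of naphthalen-1-yl on the saturated chain carbon bound to a sulfur gives a 1.3-fold higher number from compound 3 to compound 4 (0.10 log units; within the scatter) on the core without the methyl, so this position also accepts a single chlorinated aromatic ring with the chlorine at the 4-position. Together with a 1.2-fold lower number from compound 1 to compound 2 (0.10 log units; within the scatter) for the 3-chlorophenyl exchange on the methylated core, this gives two such exchanges at this position, on two cores and with two chlorine placements, and neither leaves the scatter. Nothing measured here explains why the half-life stays within the scatter across these exchanges.

Going by these compounds, whether any group at this position can move the half-life beyond the scatter remains open, for example a phenyl ring carrying a carboxylic acid or a dimethylamino group, or a longer chain in place of the single chain carbon. The compounds shown also leave open whether replacing the phenyl on the other side of the molecule with a pyridine would change the half-life in this assay.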